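A Stereocentre Drawn the Other Way

The compounds below may be only part of what the source reports. "The series", "measured", "known", "first", "only" and "open" are said of these compounds alone.

Among the compounds with values here, in a functional assay on QG-56 cells (Homo sapiens) for antiproliferative activity (a lower number here means a stronger inhibitor, a higher number a weaker inhibitor), compound 1 (`Cn1cncc1[C@@](N)(c1ccc(C#N)cc1)c1cc2cc([N+](=O)[O-])cc(-c3ccccc3)c2o1`) gives 5.9 nM, the higher of the two numbers measured so far, while compound 2 (`COc1cccc(-c2cc([N+](=O)[O-])cc3cc([C@](N)(c4ccc(C#N)cc4)c4cncn4C)oc23)c1`) gives 1.1 nM. Next comes compound 3 (`Cn1cncc1[C@](N)(c1ccc(C#N)cc1)c1cc2cc([N+](=O)[O-])cc(-c3ccccc3)c2o1`), which relates to compound 1 as follows: the two compounds have the same atoms and bonds and differ only in configuration as drawn: 1 of 1 stereo elements differ; a stereocentre at a saturated chain carbon is drawn S in compound 1 and R in compound 3. Within the data shown here, the only measured step, a 5.4-fold lower number from compound 1 to compound 2 (0.73 log units; beyond the scatter), adds a methoxy in place of hydrogen and keeps the configuration as drawn. It therefore shows how far one small change can move the number here, but it does not test configuration directly. Among the measured compounds shown here, no compound with the other configuration has been measured yet, so any forecast is uncertain. A move to a higher number, larger than the methoxy step, is expected in this assay. The expected step is an 8.5-fold higher number from compound 1 to compound 3 (0.93 log units; beyond the scatter). For compound 3 the estimated value is 50 nM, with an expected range from 6 nM to 500 nM.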

Compound 3, half-maximal inhibitory concentration: 206 nM
For compound 3 the middle estimate is 4.1-fold (0.61 log units) below the measured one; the measured number falls inside the stated range.
By their numbers in this assay, from the lowest: compound 2; then compound 1; then compound 3.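

Configuration at this saturated chain carbon matters a great deal in this assay: the step is a 35-fold higher number from compound 1 to compound 3 (1.54 log units; beyond the scatter). That is larger than the step seen with the methoxy group, a 5.4-fold lower number from compound 1 to compound 2 (0.73 log units; beyond the scatter), so among the changes shown, redrawing one stereocentre moves the number further than adding that substituent. The shift belongs to the stereocentre alone, because nothing else separates the pair: the fact that compounds 1 and 3 differ only in the configuration as drawn.

A single pair cannot show whether a gap of this size between the two configurations carries over to the methoxy-bearing compound 2. Going by these compounds, how the number would respond to a carboxylic acid in place of the nitrile, in either configuration, also remains open.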